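Swapping Methoxycarbonyl for Hydroxy in Compound 3

The source may report more compounds than this note shows. Statements on the series, on what has been measured and on what is new or still open speak of the compounds shown alone.

In an ADME assay on HEK293 cells (Homo sapiens) for cytotoxicity, with a stated time of 72 h (on this read-out higher numbers stand for an effect only at larger amounts of compound and lower numbers for an effect already at smaller amounts), compound 1 `CSc1ccc(NC(=O)Nc2cc(C)nc3ccccc23)cc1` gives 24000 nM, and compound 3 `COC(=O)c1ccc(NC(=O)Nc2cc(C)nc3ccccc23)cc1` gives 15000 nM. Among the compounds with values here, these two values lie within the scatter of each other, so compound 3 holds no separate place on the numbers so far. Compound 2 `Cc1cc(NC(=O)Nc2ccccc2N)c2ccccc2n1` gives > 25000 nM in this assay, which is a limit of the assay and not a number.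

Compound 4 `Cc1cc(NC(=O)Nc2ccc(O)cc2)c2ccccc2n1` has not yet been measured. It carries hydroxy in place of methoxycarbonyl on an aromatic carbon of a six-membered aromatic ring of carbon only, para to a large group: hydroxy in place of methoxycarbonyl on an aromatic carbon. Within the data shown here, only one measured step bears on this change, since it also exchanges one group on an aromatic carbon for another: a 1.6-fold lower number from compound 1 to compound 3 (0.20 log units; within the scatter). Because a 1.6-fold lower number from compound 1 to compound 3 (0.20 log units; within the scatter) stayed within the scatter, no change beyond the scatter is expected here. The expected step is a 1.2-fold higher number from compound 3 to compound 4 (0.08 log units; within the scatter), and this estimate rests on a single measured step. For compound 4 the estimated value in this assay is 18000 nM, with an expected range from 8000 nM to 32000 nM.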

Compound 4, half-maximal effective concentration: > 25000 nM
Compound 4: only a limit was reported (the forecaster's own chance of this, stated with the estimate: 25%); middle value at least 1.3-fold (0.14 log units) away from the limit.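

With hydroxy at this place, para to a large group, compound 4 reaches only a limit in this assay, not a number, whereas methoxycarbonyl and methylsulfanyl at the same place both gave numbers. Hydroxy in place of methoxycarbonyl gives an at least 1.6-fold higher number from compound 3 to compound 4 (0.22 log units; that floor lies within the scatter), and hydroxy in place of methylsulfanyl gives an at least 1.0-fold higher number from compound 1 to compound 4 (0.01 log units; that floor lies within the scatter), so neither floor shows a change beyond the scatter. The step between compound 2 and compound 4 cannot be read, and the other two have no upper bound, since the values stop at a limit: the limit of > 25000 nM in this assay, at which 2 of the 4 values shown sit.

As far as these compounds go, how far compound 4 lies past its limit stays open, and so does whether the change is real at all. From the compounds shown here alone, it is also open whether a methoxy group, an amine or a carboxylic acid at this place would give a number or a limit.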